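A few compounds are considered here, and "the series" means these few. Any claim that something is new, unique, unknown or untested is made for them only; others in the source may bear on it.

In an ADME assay on HepG2 2.2.15 cells (Homo sapiens) for cytotoxicity, read by CCK-8 assay, with a stated time of 8 days (on this read-out lower numbers stand for higher toxicity in this test and higher numbers for lower toxicity in this test), compound 1 (`Cc1cccc(-c2cc(NC(=O)c3ccccc3O)c[nH]c2=O)c1`) gives 98800 nM. Compound 2 (`COc1ccc(C(=O)Nc2c[nH]c(=O)c(-c3cccc(C)c3)c2)c(O)c1`) stands at > 100000 nM, which is a limit of the assay and not a number. Compound 3 (`COc1ccc(C(=O)Nc2c[nH]c(=O)c(-c3ccc(OC)c(F)c3)c2)c(O)c1`) differs from compound 2 as 3-fluoro-4-methoxyphenyl in place of 3-methylphenyl on an aromatic carbon, with 3-fluoro-4-methoxyphenyl in place of 3-methylphenyl on an aromatic carbon. For the measured compounds named here, the only measured step, an at least 1.0-fold higher number from compound 1 to compound 2 (0.00 log units; that floor lies within the scatter), is a different change, methoxy in place of hydrogen, and it stays within the scatter. No step beyond the scatter is therefore expected in this assay, with the limit of > 100000 nM in this assay, at which 1 of the 2 values shown sits, as the reference point. The expected step is an at least 1.1-fold lower number from compound 2 to compound 3 (0.04 log units; that floor lies within the scatter). For compound 3 the estimated value is 90000 nM, within an expected range of 40000 nM to 180000 nM.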

Compound 3, half-maximal cytotoxic concentration: 50500 nM
Beside the measured number, compound 3's estimate is 1.8-fold (0.25 log units) above it, and the stated range covers the measured number.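

Working at this aromatic carbon, two atoms from the ring nitrogen, 3-fluoro-4-methoxyphenyl in place of 3-methylphenyl is the only change shown here, the earlier step being methoxy in place of hydrogen elsewhere. In this assay, going by these compounds, the change reads as an at least 1.9-fold lower number from compound 2 to compound 3 (0.29 log units; that floor lies within the scatter), so a real shift is not established and its full size stays unknown. Compound 2 carries a limit of the assay and not a number: the limit of > 100000 nM in this assay, at which 1 of the 3 values shown sits.

On these data alone, how the fluoro and methoxy parts would read separately stays open, as does an amine or a carboxylic acid on this phenyl ring.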